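Epimer of compound 3 in the growth assay

The source may hold more compounds than are shown below. What is called first, only, known or untested is meant among the compounds shown, and "the series" means these compounds.

Three compounds have been run in a functional assay on U-251 cells (Homo sapiens) for inhibition (a lower number here means a stronger inhibitor of growth, a higher number a weaker inhibitor of growth), and each of them returned only a limit. Compound 1 `CC(=O)CC/C=C(\C)CCC1=C(C)CCCC1(C)C` gives > 15000 nM there, which is a limit of the assay. Compound 2 `C=C1CCCC(C)(C)C1CC[C@]1(C)CC[C@@H]([C@@H](C)C(=O)O)OO1` gives > 10000 nM in this assay, again a limit. Compound 3 `CC1=C(CC/C(C)=C/CC[C@@]2(C)CC[C@@H]([C@H](C)C(=O)O)OO2)C(C)(C)CCC1` gives > 100000 nM in this assay, also a limit and not a number. Compound 3 therefore stands without a measured figure, as do the other two; the limits sit at different heights, (the limit of > 10000 nM in this assay, at which 1 of the 3 values shown sits), the limit of > 100000 nM in this assay, at which 1 of the 3 values shown sits, and (the limit of > 15000 nM in this assay, at which 1 of the 3 values shown sits), so no ordering among the three can be drawn. Among the measured compounds shown here, no step between measured compounds exists in this set.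

Compound 4 `CC1=C(CC/C(C)=C/CC[C@@]2(C)CC[C@H]([C@H](C)C(=O)O)OO2)C(C)(C)CCC1` is the next compound, and the two compounds have the same atoms and bonds and differ only in configuration as drawn: 1 of 4 stereo elements differ; a stereocentre at a saturated ring carbon is drawn S in compound 3 and R in compound 4 With compound 3 known only as a limit and the change confined to one stereocentre, no movement beyond the scatter is expected in this assay. The expected step from compound 3 to compound 4 is a number no higher from compound 3 to compound 4 (the limit leaves the size open). Compound 4 is estimated at 100000 nM in this assay, expected between 30000 nM and 300000 nM, most likely again reported as a limit.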

Compound 4, concentration for 50% growth inhibition: > 5000 nM
Compound 4: no number, only a limit; the forecaster's own chance of this, stated with the estimate: 80%; the middle value lies beyond the limit too.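

In this assay compound 4 gives > 5000 nM, a limit and not a number. Among the compounds shown here, compound 3 gives > 100000 nM, also a limit, so no step between compound 3 and compound 4 can be read. On these data alone, whether the configuration at this stereocentre changes growth inhibition in this assay stays open.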